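A few compounds are considered here, and "the series" means these few. Any claim that something is new, unique, unknown or untested is made for them only; others in the source may bear on it.

Series notes. Within the data shown here, the shared core is that of compound 1 `CN(Cc1cc(C(F)(F)F)cc(C(F)(F)F)c1)C(=O)c1cnc2ccccc2c1-c1ccccc1`, which in an in vitro assay on UC11MG cells for binding affinity to Substance-P receptor (Homo sapiens), read by radioligand binding (a higher number here means a weaker inhibitor, a lower number a stronger inhibitor), gives 0.03 nM, the lowest of the three numbers measured so far. Compound 2 `Cc1nc2ccccc2c(-c2ccccc2)c1C(=O)N(C)Cc1cc(C(F)(F)F)cc(C(F)(F)F)c1` carries a methyl in place of hydrogen on an aromatic carbon of that core and gives 3.1 nM; compound 3 `COCc1nc2ccccc2c(-c2ccccc2)c1C(=O)N(C)Cc1cc(C(F)(F)F)cc(C(F)(F)F)c1` carries a methoxymethyl in place of hydrogen on an aromatic carbon and gives 11 nM. The measured steps are a 100-fold higher number from compound 1 to compound 2 (2.01 log units; beyond the scatter) and a 370-fold higher number from compound 1 to compound 3 (2.56 log units; beyond the scatter); between the two substituted analogues the step is a 3.5-fold higher number from compound 2 to compound 3 (0.55 log units; beyond the scatter).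

Compound 4 `CN(Cc1cc(C(F)(F)F)cc(C(F)(F)F)c1)C(=O)c1c(CN)nc2ccccc2c1-c1ccccc1` is the next member, with aminomethyl in place of hydrogen on an aromatic carbon. Both measured steps from compound 1 bear on it: the small methyl already brings a large upward step, and the methoxymethyl a still larger one. Aminomethyl is another small substituent on that aromatic carbon, so a large upward step in this assay is expected, of a size between the two measured ones. The expected step is a 170-fold higher number from compound 1 to compound 4 (2.22 log units; beyond the scatter). Compound 4 is therefore estimated at 5 nM, within 1 nM to 30 nM.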

Compound 4, half-maximal inhibitory concentration: 9 nM
Compound 4: the middle estimate sits 1.8-fold (0.26 log units) below what was measured; measured number inside the range.
By their numbers in this assay, from the lowest: compound 1; then compound 2; then compounds 4 and 3 (each within the scatter of the next).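

In this assay, aminomethyl on this aromatic carbon, next to the ring nitrogen, also gives a large step (a 300-fold higher number from compound 1 to compound 4 (2.48 log units; beyond the scatter)), so all three substituents shown here lie far from compound 1. On the saturated chain carbon bound to the aromatic carbon, amino in place of methoxy does not separate the two groups (a 1.2-fold lower number from compound 3 to compound 4 (0.09 log units; within the scatter)), while amino in place of hydrogen gives a modest step (a 2.9-fold higher number from compound 2 to compound 4 (0.46 log units; beyond the scatter)), in the same direction as methoxy. Nothing on hand accounts for these steps.

From the compounds shown here alone, it remains open whether any substituent at this position can stay close to compound 1 (0.03 nM), for example a single fluorine atom or a carboxylic acid. Also open, going by these compounds, is how a longer chain carrying the amine, or a dimethylamino group in place of amino, would read.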